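Chain variation on the shared core: cytotoxicity working notes

The source may hold more compounds than are shown below. What is called first, only, known or untested is meant among the compounds shown, and "the series" means these compounds.

Measured so far:
compound 1 `C=CCn1cc(C(=O)OCC)c(=O)c2ccc(Cl)cc21` — > 50000 nM
compound 2 `CCOC(=O)c1cn(CC)c2cc(Cl)ccc2c1=O` — > 50000 nM
compound 3 `CCOC(=O)c1cn(C)c2cc(Cl)ccc2c1=O` — > 50000 nM

In a functional assay on HeLa cells (Homo sapiens) for cytotoxicity, read by MTT assay, with a stated time of 24 h (a higher number here means a weaker inhibitor, a lower number a stronger inhibitor), compound 3 sits at the limit of > 50000 nM in this assay, at which 3 of the 3 values shown sit; its value is a limit of the assay, not a number. The same holds for compound 1 and for compound 2, so no ordering among the three can be read. The three one-place changes on the saturated chain carbon bound to the aromatic nitrogen give a step that the two limits leave unreadable from compound 1 to compound 2, a step that the two limits leave unreadable from compound 1 to compound 3 and a step that the two limits leave unreadable from compound 2 to compound 3; none of them can be sized.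

Compound 4 `CCCCn1cc(C(=O)OCC)c(=O)c2ccc(Cl)cc21` differs from compound 3 by propyl in place of hydrogen on a saturated chain carbon bound to an aromatic nitrogen. Within the data shown here, the measured steps that bear on it all involve the same place and all stayed under the limit, so they give no direction and no size for this step. Compound 4 is therefore expected to remain at the limit as well, with an expected step of a number no higher from compound 3 to compound 4 (the limit leaves the size open). Compound 4 is estimated at 50000 nM, within 20000 nM to 100000 nM, most likely again reported only as a limit.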

Compound 4, half-maximal inhibitory concentration: > 50000 nM
Compound 4 gave a limit, no number; the forecaster's own chance of this, stated with the estimate: 80%; the middle value lies on the limit itself.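

No new step can be read between compound 4 and compound 1, compound 2 or compound 3, because all four results are limits and not numbers: the limit of > 50000 nM in this assay, at which 4 of the 4 values shown sit.

The compounds shown leave open whether any chain on the shared core gives a readable value, and how these four would order.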